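The compounds below may be only part of what the source reports. "The series", "measured", "known", "first", "only" and "open" are said of these compounds alone.

Measured compounds in a functional assay (strain AB) with Danio rerio as the target, read by microscopy, with a stated time of 1 h; on this read-out higher numbers stand for an effect only at larger amounts of compound and lower numbers for an effect already at smaller amounts:
- compound 1 `NC(=O)c1c(NC(=O)Nc2ccc(Cl)cc2)sc2c1CCN(C1CCOCC1)C2`: compound 1 gives 2830 nM
- compound 2 `CCN1CCc2c(ccc(NC(=O)Nc3ccc(Cl)cc3)c2C(N)=O)C1`: compound 2 reaches only the limit of the assay, > 25000 nM, not a number
- compound 3 `CCN1Cc2sc(NC(=O)Nc3ccc(Cl)cc3)c(C(N)=O)c2C1`: compound 3 gives 4340 nM

Of the three, only compound 1 and compound 3 give actual numbers, and those two numbers sit within the usual scatter of each other, so neither can be called the more effective. Compound 2 stands apart because of the limit of > 25000 nM in this assay, at which 1 of the 3 values shown sits, a limit rather than a measured value.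

Compound 4 `CC(C)N1CCc2c(sc(NC(=O)Nc3ccc(Cl)cc3)c2C(N)=O)C1` is not yet measured. It differs from compound 1 in one place: isopropyl in place of oxan-4-yl on an amine nitrogen in a ring. The change is a swap of a ring for a short chain on the same ring nitrogen, leaving the rest of the shared core untouched. Among the compounds with values here, no measured pair here shows what such a swap does, so the expectation rests on compound 1 alone, which gives 2830 nM. The step is expected to stay small, with no clear direction beyond the scatter. Compound 4 is estimated at 3500 nM, within a range from 1200 nM to 10000 nM, which would mean a step of a 1.2-fold higher number from compound 1 to compound 4 (0.09 log units; within the scatter).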

Compound 4, half-maximal effective concentration: 1490 nM
Estimate against measurement, compound 4: 2.3-fold (0.37 log units) above, within the range that was stated.
By their numbers in this assay, from the lowest: compounds 4, 1 and 3 (each within the scatter of the next, the first and the last beyond it). At a limit, above all of these: compound 2.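

In this assay the swap of oxan-4-yl for isopropyl on this ring nitrogen gives a 1.9-fold lower number from compound 1 to compound 4 (0.28 log units; within the scatter) and so leaves the two compounds indistinguishable. Within the data shown here, this is the first sign that the position tolerates a change of group: neither the ring nor its oxygen is needed to keep the number at this level, and a short chain serves as well. No measurement shown explains why the two compounds sit so close.

Going by these compounds, only these two groups can be compared at this position, so how far its tolerance reaches remains open. A bulkier benzyl group, a longer chain ending in a carboxylic acid or a primary amine, or a plain hydrogen on the same nitrogen could each test that limit.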